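The compounds below may be only part of what the source reports. "The series", "measured", "known", "first", "only" and "open" are said of these compounds alone.

Series notes. The shared core carries a sulfonamide; compound 1 is `O=S(=O)(Nc1ccc2oc(-c3ccccc3)nc2c1)c1ccccc1C(F)(F)F` and compound 2 is `O=S(=O)(Nc1ccc2oc(-c3ccccc3)nc2c1)c1ccccc1Cl`. In an assay on cells for inhibition of HSP60/HSP10 (Homo sapiens), with a stated time of 60 min (a lower number here means a stronger inhibitor, a higher number a weaker inhibitor), compound 1 gives only a limit of the assay, > 100000 nM. In this assay compound 2 likewise gives only a limit, > 100000 nM. Within the data shown here, the one measured step, a step that the two limits leave unreadable from compound 1 to compound 2, can therefore not be read in size or direction, as the limit of > 100000 nM in this assay, at which 2 of the 2 values shown sit, shows. Compound 2 thus stands at the limit, with no number to place it against. Compound 3, `CS(=O)(=O)Nc1ccc2oc(-c3ccccc3)nc2c1`, is not yet measured; its change from compound 2 is methyl in place of 2-chlorophenyl on a sulfonyl sulfur. Among the measured compounds shown here, no measured step bears on this change: the only step recorded, from the trifluoromethyl to the chloro compound, touches the 2-chlorophenyl part rather than the group on the sulfonyl sulfur, and is itself unreadable. No step beyond the scatter can be foreseen in this assay in either direction; the expectation is simply that compound 3 also sits at a limit. For compound 3 the estimated value in this assay is 150000 nM, within a range from 30000 nM to 1000000 nM. The step this estimate implies, a step that the limit leaves unreadable from compound 2 to compound 3, is expected to lie within the scatter.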

Compound 3, half-maximal inhibitory concentration: > 100000 nM
Compound 3 gave a limit, no number; the forecaster's own chance of this, stated with the estimate: 85%; the middle value is on the limit's open side.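

In this assay compound 3 gives > 100000 nM which is a limit and not a number. No step can be read between compound 2 and compound 3, and compounds 1, 2 and 3 all sit at the same limit: the limit of > 100000 nM in this assay, at which 3 of the 3 values shown sit. The compounds shown leave open which change to the shared core, if any, gives a readable value in this assay for this series.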